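Replacing the 3-nitrophenyl group of compound 3

The compounds below may be only part of what the source reports. "The series", "measured", "known", "first", "only" and "open" are said of these compounds alone.

Of the compounds shown here, three on one shared core have been tested in a functional assay on Bel-7402 cells (Homo sapiens) for cytotoxicity, read by MTT assay (a higher number here means a weaker inhibitor, a lower number a stronger inhibitor), and compound 1 (`CCn1cc(-c2nc3ccc([N+](=O)[O-])cc3o2)c(=O)c2cc(F)c(N3CCNC(C)C3)c(F)c21`) gives 1600 nM there. Compound 2 (`CCn1cc(C(=O)Nc2ccccc2)c(=O)c2cc(F)c(N3CCNC(C)C3)c(F)c21`) gives 6000 nM and compound 3 (`CCn1cc(C(=O)Nc2cccc([N+](=O)[O-])c2)c(=O)c2cc(F)c(N3CCNC(C)C3)c(F)c21`) gives 1000 nM on the same measure. The gap between compound 1 and compound 3 lies within the usual scatter, so these two cannot be told apart, and they sit together at the low end of the three numbers.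

The next structure is compound 4 (`CCn1cc(C(=O)NCc2ccc(OC)cc2)c(=O)c2cc(F)c(N3CCNC(C)C3)c(F)c21`), which carries 4-methoxybenzyl in place of 3-nitrophenyl on an amide-type nitrogen. The nitro group is therefore lost. Among the measured compounds shown here, the one measured step that bears on this is a 6.0-fold lower number from compound 2 to compound 3 (0.78 log units; beyond the scatter) where nitro took the place of hydrogen on an aromatic carbon. Losing the nitro might undo much of that step, but none of the tested compounds carries 4-methoxybenzyl, so the guide is only partial.

In this assay the expected change is a 3.5-fold higher number from compound 3 to compound 4 (0.54 log units; beyond the scatter) and it points toward a weaker inhibitor. The estimated value for compound 4 is 3500 nM with an expected range from 1000 nM to 12000 nM until a measurement arrives.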

Compound 4, half-maximal inhibitory concentration: 10300 nM
Beside the measured number, compound 4's estimate is 2.9-fold (0.47 log units) below it, and the stated range covers the measured number.
By their numbers in this assay, from the lowest: compounds 3 and 1 (each within the scatter of the next); then compounds 2 and 4 (each within the scatter of the next).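

In this assay, the group on the amide-type nitrogen clearly matters: 4-methoxybenzyl in place of 3-nitrophenyl gives a 10-fold higher number from compound 3 to compound 4 (1.01 log units; beyond the scatter), the largest step on this core so far. Set against the plain phenyl group, 4-methoxybenzyl gives a 1.7-fold higher number from compound 2 to compound 4 (0.23 log units; within the scatter), so these two compounds cannot be told apart, and among the three amides only the one carrying 3-nitrophenyl stands apart, with a lower number than the other two. Nothing at hand gives a reason for this pattern.

Compound 4 differs from compound 3 in several features at once, including the nitro group, the methoxy group and the benzyl link, so the data cannot say how much of the large step belongs to each; 3-nitrobenzyl and 4-methoxyphenyl on the same nitrogen would begin to separate them. As far as these compounds go, it also remains open whether the low number of compound 3 is specific to nitro, or whether another group on the same aromatic ring, such as a nitrile or a carboxylic acid, would give a similar result in this assay.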